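Removing the hydroxyl from the indanylamine of compound 2

The source may hold more compounds than are shown below. What is called first, only, known or untested is meant among the compounds shown, and "the series" means these compounds.

Compound 1, `CN(Cc1cccs1)C1CCN(CCCc2c[nH]c3ccc(-n4cnnc4)cc23)CC1`: 81%
Compound 2, `O[C@@H]1Cc2ccccc2[C@H]1NC1CCN(CCCc2c[nH]c3ccc(-n4cnnc4)cc23)CC1`: 75%

In a functional assay on CHO cells for activation of 5-hydroxytryptamine receptor 1D (Homo sapiens), read by GTPgammaS binding (on this read-out higher numbers stand for larger maximal responses and lower numbers for smaller maximal responses), compound 1 gives 81%, and compound 2 gives 75%. For the measured compounds named here, the one measured step, a number 6 percentage points lower from compound 1 to compound 2 (within the scatter), lies within the scatter, so on these two numbers compound 2 and compound 1 cannot be told apart.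

Compound 3, `c1ccc2c(c1)CCC2NC1CCN(CCCc2c[nH]c3ccc(-n4cnnc4)cc23)CC1`, is the not yet measured partner of compound 2. It differs in one place: 2,3-dihydro-1H-inden-1-yl in place of 2-hydroxy-2,3-dihydro-1H-inden-1-yl on an amine nitrogen. Going by the values given here, no measured pair shows what the loss of this hydroxyl does; the only step known, a number 6 percentage points lower from compound 1 to compound 2 (within the scatter), changes the whole group on that ring carbon and stays within the scatter. The expectation therefore rests on compound 2 alone, with no direction supported by any step. For compound 3 the estimate in this assay is 75%, within 55% to 95%, which is expected to correspond to a step of no change at the digits printed from compound 2 to compound 3 (within the scatter) and so to none beyond the scatter.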

Compound 3, largest response reached (reported as efficacy), in percent of the reference or control that the assay uses: 68%
Beside the measured number, compound 3's estimate is 7 percentage points above it, and the stated range covers the measured number.
By their numbers in this assay, from the lowest: compounds 3, 2 and 1 (each within the scatter of the next, the first and the last beyond it).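

Losing the hydroxyl on the amine nitrogen gives a number 7 percentage points lower from compound 2 to compound 3 (within the scatter) in this assay, so this change cannot be told from no change on these numbers. For the compounds shown here, the other new step, a number 13 percentage points lower from compound 1 to compound 3 (beyond the scatter), is the first beyond the scatter and shows that (2,3-dihydro-1H-inden-1-yl)amino in place of methyl((thiophen-2-yl)methyl)amino on a saturated ring carbon can shift the maximal response modestly, while compound 2 stays within the scatter of both neighbours. No supporting measurement bears on the reason for either step.

Compound 3 also lacks the defined stereocentres of compound 2, so the compounds shown do not separate the hydroxyl from the stereochemistry. They also leave open what a methoxy or an amino group would do in place of that hydroxyl.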